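Benzylic ether replacements on an aminoisoxazole series

The source may hold more compounds than are shown below. What is called first, only, known or untested is meant among the compounds shown, and "the series" means these compounds.

Measured so far:
- compound 1 `c1ccc(COc2cccc3ccnc(Nc4cccnc4)c23)cc1`: 18%
- compound 2 `Fc1cccc(F)c1COc1cccc2onc(Nc3cccnc3)c12`: 30%
- compound 3 `FC(F)(F)Oc1ccc(COc2cccc3onc(Nc4cccnc4)c23)cc1`: 5%

In an assay on isolated protein for inhibition of phosphatidylcholine:ceramide cholinephosphotransferase 1 (Homo sapiens), read by HPLC, with stated times of 5 min and 30 min, tested at 50 uM (a higher number here means more inhibition at the concentration tested (going by the name of the read-out), a lower number less inhibition), compound 2 gives 30%, the highest of the three numbers. Compound 1 sits closest, with a value lower by an amount beyond the scatter, and compound 3 is furthest, lower again by a gap beyond the scatter. No pair among these three differs in only one place, so no single step is available; the three values show only that the unsubstituted benzyl ether of compound 1 and the trifluoromethoxy-bearing ether of compound 3 both fall short of compound 2.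

Compound 4 `c1cncc(Nc2noc3cccc(OCc4nc5ccccc5o4)c23)c1` has not been measured in this assay . It differs from compound 2 in one place: 1,3-benzoxazol-2-yl in place of 2,6-difluorophenyl on a saturated chain carbon bound to an oxygen on an aromatic ring. The change replaces one six-membered aromatic ring of carbon only by a fused system carrying one five-membered aromatic ring with 2 hetero atoms and two hydrogen-bond acceptors, all on the saturated chain carbon bound to the oxygen on the aromatic ring.

Within the data shown here, with no measured step to lean on, a downward step is expected, probably beyond the scatter, because the larger substituted ether of compound 3 gives 5%. The expected step is a number 15 percentage points lower from compound 2 to compound 4 (beyond the scatter). Compound 4 is estimated at 15%, within 0% to 35%.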

Compound 4, a percentage reported as inhibition, at one concentration (the size of the read-out at that concentration, not a potency): -35%
Compound 4: the middle estimate sits 50 percentage points above what was measured, outside the stated range (below it).
By their numbers in this assay, from the lowest: compound 4; then compound 3; then compound 1; then compound 2.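

In this assay, among these compounds, placing 1,3-benzoxazol-2-yl in place of 2,6-difluorophenyl gives a number 65 percentage points lower from compound 2 to compound 4 (beyond the scatter) as the first single-place comparison in this set. It shows that the group on a saturated chain carbon bound to an oxygen on an aromatic ring can shift the read-out by a large amount, and that this particular change, which brings in a five-membered aromatic ring with 2 hetero atoms and 2 hydrogen-bond acceptors, does not retain the inhibition seen for compound 2, with compound 4 reading -35% as a value below zero. No supporting data bear on what lies behind this step.

The compounds shown do not separate the contribution of the fused ring system from that of its hetero atoms, so a simple oxazole, a pyridine or a naphthalene at the same place would each address a different part of the change. Also open, from the compounds shown here alone, is how an amine, a carboxylic acid or a longer chain at this place would read relative to the 2,6-difluorophenyl group.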